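Series notes: cytotoxicity and the tert-butyl step to compound 4

The compounds below may be only part of what the source reports. "The series", "measured", "known", "first", "only" and "open" are said of these compounds alone.

Measured so far in a functional assay on HeLa cells (Homo sapiens) for cytotoxicity, read by MTT assay, with a stated time of 48 h; on this read-out higher numbers stand for weaker inhibition and lower numbers for stronger inhibition:
compound 1 `O=c1ccoc2cc(OCc3cn(Cc4ccccc4)nn3)ccc12`: > 100000 nM
compound 2 `O=c1ccoc2cc(OCc3cn(Cc4cccc(Br)c4)nn3)ccc12`: > 100000 nM
compound 3 `O=c1ccoc2cc(OCc3cn(Cc4ccccc4F)nn3)ccc12`: > 100000 nM

Compound 1 stands at the limit of this assay, not at a number. Compound 2 likewise returns only a limit. The same holds for compound 3. All three values sit at the limit of > 100000 nM in this assay, at which 3 of the 3 values shown sit, so the step that the two limits leave unreadable from compound 1 to compound 2, the step that the two limits leave unreadable from compound 1 to compound 3 and the step that the two limits leave unreadable from compound 2 to compound 3 are all unreadable in size and direction; nothing in the measured set places any of these compounds relative to another.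

Compound 4 `CC(C)(C)c1ccc(Cn2cc(COc3ccc4c(=O)ccoc4c3)nn2)cc1` differs from compound 1 by tert-butyl in place of hydrogen on an aromatic carbon. The measured steps that bear on a substituent on an aromatic carbon of that ring are those from compound 1 to compound 2 and from compound 1 to compound 3, and both leave the read-out at the limit, so neither gives a size that could be carried over. The step of a number no higher from compound 1 to compound 4 (the limit leaves the size open) is therefore expected to be none that can be separated from the scatter, with the read-out most probably a limit once more. Compound 4 is estimated at 100000 nM, with a range from 30000 nM to 300000 nM.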

Compound 4, half-maximal inhibitory concentration: 17600 nM
The estimate for compound 4 lay 5.7-fold (0.75 log units) above the measured number; measured number outside the range, below it.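

In this assay, tert-butyl on an aromatic carbon of the six-membered aromatic ring of carbon only, para to a large group, gives an at least 5.6-fold lower number from compound 1 to compound 4 (0.75 log units; beyond the scatter), and compound 4 with 17600 nM is the only compound shown with a read-out that is a number. Change at this ring can therefore move the read-out out of the limit, which compounds 2 and 3 did not show: with bromo and fluoro on the same ring, both remain at the limit, so the effect cannot be claimed for substituents on this ring in general. The true size of the step stays open, because compound 1 itself gives only a limit, as do compounds 2 and 3: the limit of > 100000 nM in this assay, at which 3 of the 4 values shown sit.

The compounds shown leave open whether a methyl group, a methoxy group, an amine or a carboxylic acid at the same place would move the read-out as tert-butyl does, or whether tert-butyl stands alone. They also leave open whether tert-butyl placed elsewhere on that ring would give a number at all, and whether a longer chain on the core of compound 1 would do so.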